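Swapping a Fluorophenyl for a Methylphenyl on a Shared Core

A few compounds are considered here, and "the series" means these few. Any claim that something is new, unique, unknown or untested is made for them only; others in the source may bear on it.

All three measured compounds share the core seen in compound 3 `C=CCn1c(=O)/c(=C\c2ccccc2F)[nH]c(=O)/c1=C\c1ccccc1OC`, differing only in the aryl group on a double-bonded chain carbon bound to an aromatic carbon. In a functional assay on HeLa cells (Homo sapiens) for cytotoxicity, read by CCK-8 assay, with a stated time of 72 h (a higher number here means a weaker inhibitor, a lower number a stronger inhibitor), compound 3 gives 45000 nM, the highest number among the measured values and so the weakest measured inhibitor. Compound 1 `C=CCn1c(=O)/c(=C\c2cccc(F)c2)[nH]c(=O)/c1=C\c1ccccc1OC` gives 9100 nM in this assay. Compound 2 `C=CCn1c(=O)/c(=C\c2ccc(F)c(Br)c2)[nH]c(=O)/c1=C\c1ccccc1OC` is reported in this assay as "not active" (no number reported), with no number. Within the data shown here, the only measured step, a 4.9-fold higher number from compound 1 to compound 3 (0.69 log units; beyond the scatter), shows that moving the fluorine on this ring shifts the number beyond the scatter.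

Compound 4 `C=CCn1c(=O)/c(=C\c2ccc(C)cc2)[nH]c(=O)/c1=C\c1ccccc1OC` differs from compound 3 as follows: 4-methylphenyl in place of 2-fluorophenyl on a double-bonded chain carbon bound to an aromatic carbon. Among the measured compounds shown here, no measured step involves a methyl group, and compound 2, which carries two halogens on this ring, is not active, so the data give no direct guide. Compound 4 is expected to stay close to compound 3, with a step of a 1.5-fold lower number from compound 3 to compound 4 (0.18 log units; within the scatter) expected to lie within the scatter. The estimate for compound 4 is 30000 nM, with a wide range from 8000 nM to 100000 nM.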

Compound 4, half-maximal inhibitory concentration: "not active" (no number reported)
Compound 4: no number reported; no gap can be computed for the estimate.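

Among these compounds, compound 4 is reported as "not active" in this assay, with no number, so no step from compound 3 to compound 4 can be read. Nothing shown here explains this result. The compounds shown leave open how compound 2 and compound 4 compare numerically with compound 3.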